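From Methoxy(methyl)carbamoyl to Carbamoyl on a Shared Core

A few compounds are considered here, and "the series" means these few. Any claim that something is new, unique, unknown or untested is made for them only; others in the source may bear on it.

The measured compounds and their values:
Compound 1, `CONC(=O)[C@@H]1CC=C(CCC=C(C)C)C[C@H]1c1ccccc1`: 2700 nM
Compound 2, `CC(C)=CCCC1=CC[C@@H](C(=O)N(C)C)[C@H](c2ccccc2)C1`: > 23000 nM
Compound 3, `CON(C)C(=O)[C@@H]1CC=C(CCC=C(C)C)C[C@H]1c1ccccc1`: > 23000 nM

In an assay on isolated protein for inhibition of Apoptosis regulator Bcl-2 (Homo sapiens), read by fluorescence polarization, with stated times of 5 min and 10 min (a higher number here means a weaker inhibitor, a lower number a stronger inhibitor), compound 1 gives 2700 nM and is the only one of the three with a numerical result. For compound 2 the assay reports only its limit, > 23000 nM. For compound 3 as well the result is a limit, > 23000 nM, so compound 3 stands at the weak end of what is shown, with no number of its own; this is the limit of > 23000 nM in this assay, at which 2 of the 3 values shown sit.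

Compound 4, `CC(C)=CCCC1=CC[C@@H](C(N)=O)[C@H](c2ccccc2)C1`, differs from compound 3 by amino in place of methoxy(methyl)amino on a carbonyl carbon. For the measured compounds named here, two measured steps bear on this change. The step of an at least 8.5-fold higher number from compound 1 to compound 2 (0.93 log units; beyond the scatter) and the step of an at least 8.5-fold higher number from compound 1 to compound 3 (0.93 log units; beyond the scatter) both take away the hydrogen on the amide-type nitrogen of compound 1 and both push the number past the limit. The step that the two limits leave unreadable from compound 2 to compound 3 cannot be read, since both ends sit at the limit. The change from compound 3 to compound 4 runs the other way, returning a hydrogen-bond donor to that nitrogen, so a step downward beyond the scatter is expected, an at least 4.6-fold lower number from compound 3 to compound 4 (0.66 log units; beyond the scatter), bringing compound 4 toward compound 1. Compound 4 is therefore estimated at 5000 nM, within 1500 nM to 20000 nM.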

Compound 4, inhibition constant: > 23000 nM
Compound 4 was reported as a limit; the forecaster's own chance of this, stated with the estimate: 30%; middle value at least 4.6-fold (0.66 log units) from the limit.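

In this assay compound 4 is also reported only as a limit, > 23000 nM. With hydrogen in place of methoxy on the amide-type nitrogen, the result is an at least 8.5-fold higher number from compound 1 to compound 4 (0.93 log units; beyond the scatter), so returning a hydrogen to that nitrogen is not enough on its own to give a numerical result. Compound 3 keeps the methoxy but lacks the amide hydrogen, compound 4 keeps the amide hydrogen but lacks the methoxy, and both end past the limit, so among the groups shown on this carbonyl carbon only the methoxyamino group of compound 1 gives a number, while the steps among compound 2, compound 3 and compound 4 cannot be read, as all three sit at one limit: the limit of > 23000 nM in this assay, at which 3 of the 4 values shown sit.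

The compounds shown leave open whether the methoxy itself is needed or whether another group on that nitrogen, such as hydroxy, ethoxy or a plain methyl in a methylamino group, would also give a number. They also leave open how far compound 2, compound 3 and compound 4 lie beyond the limit, and whether they differ from one another at all.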